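This account rests on a few compounds, and the source may have more. Where it says the series, first, only, none or still open, it means among the compounds named here.

Measured compounds:
- Compound 1, `Cn1ncc2c(=O)n(-c3ccccc3)c(CNc3cccc(F)c3)nc21`: 1050 nM
- Compound 2, `Cn1ncc2c(=O)n(-c3ccccc3)c(SCc3cccc(F)c3)cc21`: 140 nM

Both were tested in an assay on isolated protein for inhibition of Retinaldehyde dehydrogenase 3 (Homo sapiens); a lower number here means a stronger inhibitor, a higher number a weaker inhibitor. Of the two, compound 1 has the higher number, so it is the weaker inhibitor here; compound 2, with its lower number, sits apart from it by a gap that goes beyond the usual scatter. The two compounds differ in more than one place, so no single change can be read out of that gap.

Compound 3, `Cn1ncc2c(=O)n(-c3ccccc3)c(COc3cccc(F)c3)nc21`, has not yet been measured in this assay. It is built from compound 1 by one change: 3-fluorophenoxy in place of (3-fluorophenyl)amino on a saturated chain carbon bound to an aromatic carbon. The donor that the (3-fluorophenyl)amino group carries is no longer there; the 3-fluorophenoxy group keeps an acceptor only.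

Going by the values given here, no measured pair shows this exact change, so the expectation rests on compound 1 alone. The step from compound 1 to compound 3 is expected to be small, at most a modest rise in the number, that is a 1.4-fold higher number from compound 1 to compound 3 (0.15 log units; within the scatter). For compound 3 the estimated value in this assay is 1500 nM, with a likely range from 500 nM to 5000 nM.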

Compound 3, half-maximal inhibitory concentration: 780 nM
For compound 3 the middle estimate is 1.9-fold (0.28 log units) above the measured one; low and high end bracket the measured number.
By their numbers in this assay, from the lowest: compound 2; then compounds 3 and 1 (each within the scatter of the next).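

In this assay, replacing the (3-fluorophenyl)amino group with 3-fluorophenoxy on a saturated chain carbon bound to an aromatic carbon gives a 1.3-fold lower number from compound 1 to compound 3 (0.13 log units; within the scatter) and leaves the two compounds indistinguishable. This is the first pair shown that differs in one place only, so this single change can be read directly, which the earlier pair did not allow. Here the hydrogen-bond donor of the (3-fluorophenyl)amino group is lost and the nitrogen link becomes an oxygen link, yet the number does not move beyond the usual scatter, and no separate measurement bears on why the two numbers stay so close.

Compound 2 stands at 140 nM but differs from compound 1 in more than one place, so the individual contributions of its differences remain unresolved. Going by these compounds alone, also open is how the number would respond at this place to an amide link or a longer chain between the core and the fluorophenyl ring, since the two groups compared here show only that this one exchange of nitrogen for oxygen leaves the number within the scatter.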